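Methyl added on compound 2, with both values at a limit

The compounds below may be only part of what the source reports. "The series", "measured", "known", "first", "only" and "open" are said of these compounds alone.

Measured in a functional assay on RAW264.7 cells (Mus musculus) for inhibition, read by microscopy and resazurin assay, with a stated time of 72 h; on this read-out lower numbers stand for stronger inhibition and higher numbers for weaker inhibition:
compound 1 `C=CCONC(=O)Cn1cc(C(=O)N[C@@H](C)C(=O)N[C@H](C(=O)O)C(C)C)c2ccccc21` gives > 128000 nM, a limit of the assay.
compound 2 `CC(C)[C@H](NC(=O)CNC(=O)c1cn(CC(=O)NOCc2ccccc2)c2ccccc12)C(=O)O` gives > 128000 nM, a limit of the assay.

Compound 2 stands where every value shown stands: the limit of > 128000 nM in this assay, at which 2 of the 2 values shown sit. No ordering between the two measured compounds is possible. Compound 3 `CC(C)[C@H](NC(=O)[C@H](C)NC(=O)c1cn(CC(=O)NOCc2ccccc2)c2ccccc12)C(=O)O` differs from compound 2 by methyl in place of hydrogen on a saturated chain carbon bound to an amide-type nitrogen and a carbonyl carbon. For the measured compounds named here, no step between measured compounds is known. Compound 1 already sits at the same limit. The expected step is therefore a number no higher from compound 2 to compound 3 (the limit leaves the size open), none beyond the scatter. Compound 3 is estimated at 128000 nM, in the range 40000 nM to 400000 nM, most probably reported again only as a limit.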

Compound 3, half-maximal inhibitory concentration: > 128000 nM
Compound 3: a limit, no number; the forecaster's own chance of this, stated with the estimate: 85%; the middle value sits exactly at the limit.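

No step can be read from compound 1, compound 2 or compound 3 in this assay, since each value is a limit: the limit of > 128000 nM in this assay, at which 3 of the 3 values shown sit.
The compounds shown leave open how strongly any of them inhibits, and whether methyl in place of hydrogen changes that.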